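This account rests on a few compounds, and the source may have more. Where it says the series, first, only, none or still open, it means among the compounds named here.

Measured in a functional assay on SW-620 cells (Homo sapiens) for cytotoxicity, read by MTT assay, with stated times of 4 h and 72 h, tested at 2 uM; on this read-out lower numbers stand for stronger inhibition and higher numbers for weaker inhibition:
compound 1 `COc1ccc(/C=C/C(=O)c2ccc(Nc3cc(C)nc4nc(SCc5nc6ccccc6[nH]5)nn34)cc2)cc1F`: 140 nM
compound 2 `Cc1cc(Nc2ccc(C(=O)/C=C/c3ccc(F)cc3)cc2)n2nc(SCc3nc4ccccc4[nH]3)nc2n1`: 85 nM

Within the data shown here, compound 1 lies within the scatter of compound 2, the only other measured compound, so the two numbers cannot be ranked. Compound 3 `COc1ccc(/C=C/C(=O)c2ccc(Nc3cc(C)nc4nc(SCc5nc6ccccc6[nH]5)nn34)cc2)cc1` differs from compound 1 by hydrogen in place of fluoro on an aromatic carbon, ortho to a methoxy group. Among the measured compounds shown here, one measured step bears on this aryl group. In a 1.6-fold lower number from compound 1 to compound 2 (0.22 log units; within the scatter), 4-fluorophenyl replaces 3-fluoro-4-methoxyphenyl, and that step stays within the scatter. No measurement isolates the fluoro alone, so this evidence is thin. Even so, no step beyond the scatter is expected in this assay. The expected change is small, a 1.1-fold lower number from compound 1 to compound 3 (0.03 log units; within the scatter). For compound 3 the estimated value is 130 nM, with an expected range from 55 nM to 320 nM.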

Compound 3, half-maximal inhibitory concentration: 170 nM
Estimate against measurement, compound 3: 1.3-fold (0.12 log units) below; measured number inside the range.
By their numbers in this assay, from the lowest: compounds 2, 1 and 3 (each within the scatter of the next).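

Compound 3 isolates the fluoro, ortho to a methoxy group, which the earlier pair could not do: in this assay hydrogen in place of fluoro on an aromatic carbon gives a 1.2-fold higher number from compound 1 to compound 3 (0.08 log units; within the scatter) and so shows no effect of this single atom that can be told from the scatter. Methoxy in place of fluoro on an aromatic carbon gives a 2.0-fold higher number from compound 2 to compound 3 (0.30 log units; within the scatter) and also stays within the scatter, so 4-methoxyphenyl and 4-fluorophenyl cannot be ranked in this position. No supporting measurement is available to explain these results.

The compounds shown leave open whether an amine or a carboxylic acid on this aromatic carbon would give a step beyond the scatter. They also leave open whether a longer chain in place of the methoxy group would do so.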